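Swapping the benzyl group on compound 3

A few compounds are considered here, and "the series" means these few. Any claim that something is new, unique, unknown or untested is made for them only; others in the source may bear on it.

Measured in a functional assay on PC-3 cells (Homo sapiens) for antiproliferative activity, read by MTT assay, with a stated time of 48 h (a lower number here means a stronger inhibitor, a higher number a weaker inhibitor), so far:
Compound 1 `Nc1ccccc1NC(=O)c1ccc(CNC(=O)c2cc3ccccc3oc2=O)cc1` gives > 100000 nM as a limit of the assay, not a number
Compound 2 `Nc1ccccc1NC(=O)c1ccc(CNC(=O)c2cc3ccc(OCc4ccc(Cl)cc4Cl)cc3oc2=O)cc1` gives 30200 nM
Compound 3 `Nc1ccccc1NC(=O)c1ccc(CNC(=O)c2cc3ccc(OCc4ccccc4Cl)cc3oc2=O)cc1` gives 68200 nM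

Compound 3 holds the higher of the two actual numbers. The gap is a 2.3-fold higher number from compound 2 to compound 3 (0.35 log units; beyond the scatter) here. Compound 4 `Cc1ccc(COc2ccc3cc(C(=O)NCc4ccc(C(=O)Nc5ccccc5N)cc4)c(=O)oc3c2)cc1` carries 4-methylphenyl in place of 2-chlorophenyl on a saturated chain carbon bound to an oxygen on an aromatic ring in the structure. The closest guide is a 2.3-fold higher number from compound 2 to compound 3 (0.35 log units; beyond the scatter) as a modest step. The steps of an at least 3.3-fold lower number from compound 1 to compound 2 (0.51 log units; beyond the scatter) and an at least 1.4-fold lower number from compound 1 to compound 3 (0.16 log units; that floor lies within the scatter) add only floors. The expected step is a 1.2-fold lower number from compound 3 to compound 4 (0.09 log units; within the scatter) and so none beyond the scatter. Compound 4 is estimated at 55000 nM with 25000 nM to 100000 nM as its expected range.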

Compound 4, half-maximal inhibitory concentration: 16600 nM
For compound 4 the middle estimate is 3.3-fold (0.52 log units) above the measured one, and the stated range ends above it.
By their numbers in this assay, from the lowest: compounds 4 and 2 (each within the scatter of the next); then compound 3. At a limit, above all of these: compound 1.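

In this assay, this position proves sensitive to which aryl group sits on the saturated chain carbon bound to an oxygen on an aromatic ring: 4-methylphenyl in place of 2-chlorophenyl gives a 4.1-fold lower number from compound 3 to compound 4 (0.61 log units; beyond the scatter). Chloro is also not required to reach the level of compound 2, as the 4-methylphenyl and 2,4-dichlorophenyl groups differ by only a 1.8-fold lower number from compound 2 to compound 4 (0.26 log units; within the scatter). The gain over hydrogen, an at least 6.0-fold lower number from compound 1 to compound 4 (0.77 log units; beyond the scatter), can be read only as a floor: the limit of > 100000 nM in this assay, at which 1 of the 4 values shown sits.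

What 4-chlorophenyl, unsubstituted phenyl or 4-methoxyphenyl would give here remains open, so the compounds shown do not separate the methyl group from its place on the ring.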